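A few compounds are considered here, and "the series" means these few. Any claim that something is new, unique, unknown or untested is made for them only; others in the source may bear on it.

Measured in a functional assay on A549 cells (Homo sapiens) for cytotoxicity, read by MTT assay, with a stated time of 72 h; on this read-out lower numbers stand for stronger inhibition and higher numbers for weaker inhibition:
- compound 1 `CC1CCN(Cc2ccc3nc(NC(=O)N/N=C/c4c[nH]c5ccccc45)sc3c2)CC1`: 3580 nM
- compound 2 `Cc1ccc(Cn2cc(/C=N/NC(=O)Nc3nc4ccc(CN5CCC(C)CC5)cc4s3)c3ccccc32)cc1`: 2180 nM

Compound 1 stands within the scatter of compound 2, the only other measured point. Compound 3 `CCN(CC)Cc1ccc2nc(NC(=O)N/N=C/c3c[nH]c4ccccc34)sc2c1` keeps the core of compound 1 and changes the group on the saturated chain carbon: diethylamino in place of 4-methylpiperidin-1-yl on a saturated chain carbon bound to an aromatic carbon.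

For the measured compounds named here, no measured step covers this place. Going by the values given here, the one available step, a 1.6-fold lower number from compound 1 to compound 2 (0.22 log units; within the scatter), is the replacement of hydrogen on an aromatic nitrogen, so it bears only indirectly, as a sign that the series has so far moved little. No shift beyond the scatter is therefore expected in this assay. The expected change is a 1.0-fold lower number from compound 1 to compound 3 (0.01 log units; within the scatter). For compound 3 the estimate is 3500 nM, with an expected range of 1500 nM to 8000 nM.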

Compound 3, half-maximal inhibitory concentration: 3300 nM
Compound 3: the middle estimate sits 1.1-fold (0.03 log units) above what was measured, and the stated range covers the measured number.
By their numbers in this assay, from the lowest: compounds 2, 3 and 1 (each within the scatter of the next).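

At the saturated chain carbon bound to an aromatic carbon, diethylamino in place of 4-methylpiperidin-1-yl gives a 1.1-fold lower number from compound 1 to compound 3 (0.04 log units; within the scatter) in this assay. For this pair, then, the six-membered non-aromatic ring can give way to an open-chain amine without a change beyond the scatter. No other data bear on this result.

Open, from the compounds shown here alone, is whether morpholine, piperazine or a carboxylic acid at this place would move the number beyond the scatter. Also open, going by these compounds, is how diethylamino reads alongside the 4-methylbenzyl group of compound 2.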